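The source may hold more compounds than are shown below. What is called first, only, known or untested is meant among the compounds shown, and "the series" means these compounds.

Measured in a functional assay on HL60/MX2 cells (Homo sapiens) for antiproliferative activity, read by MTT assay, with a stated time of 48 h; on this read-out lower numbers stand for stronger inhibition and higher numbers for weaker inhibition:
- compound 1 `Cn1c(N)c(-c2nc3ccccc3[nH]2)c2nc(C#N)c(C#N)nc21`: > 50000 nM (a limit, not a number)
- compound 2 `CCN(CC)CCn1c(N)c(-c2nc3ccccc3[nH]2)c2nc(C#N)c(C#N)nc21`: 7150 nM
- compound 3 `CCCn1c(N)c(-c2nc3ccccc3[nH]2)c2nc(C#N)c(C#N)nc21`: > 50000 nM (a limit, not a number)

Compound 3 has no exact value, only the limit > 50000 nM. This is the limit of > 50000 nM in this assay, at which 2 of the 3 values shown sit. All that can be said is that it sits at the weak end of what was measured here.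

Compound 4 `CN(C)CCCn1c(N)c(-c2nc3ccccc3[nH]2)c2nc(C#N)c(C#N)nc21` is compound 3 with one change: dimethylamino in place of hydrogen on a saturated chain carbon, three bonds along the chain from an aromatic nitrogen. This turns propyl into 3-(dimethylamino)propyl.

Going by the values given here, two measured steps bear on this change: an at least 6.9-fold lower number from compound 1 to compound 2 (0.84 log units; beyond the scatter) and an at least 6.9-fold higher number from compound 2 to compound 3 (0.84 log units; beyond the scatter). In both, the diethylamino group goes with the lower number, and both sizes are bounded by the limit, so the true gaps may be larger. Among these three compounds, only compound 2 carries an amino group on its chain, and only compound 2 gives a number. That is a single observation, and in compound 4 the amino group is a different one, at a different place on the chain. A step to a lower number is therefore expected, of roughly the same size as those two. The expected step is an at least 5.5-fold lower number from compound 3 to compound 4 (0.74 log units; beyond the scatter). For compound 4 the estimated value is 9000 nM, with an expected range from 3000 nM to 35000 nM.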

Compound 4, half-maximal inhibitory concentration: 2390 nM
The estimate for compound 4 lay 3.8-fold (0.58 log units) above the measured number; the measured number lies below the stated range.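

In this assay, the step from a plain propyl chain to 3-(dimethylamino)propyl is large, at an at least 20-fold lower number from compound 3 to compound 4 (1.32 log units; beyond the scatter), and the comparison with the shorter chain-free substituent of compound 1 gives an at least 20-fold lower number from compound 1 to compound 4 (1.32 log units; beyond the scatter), so among these four compounds the two with an amino group on the chain are the two that give a number. The two amine-bearing chains also differ from each other beyond the scatter, with a 3.0-fold lower number from compound 2 to compound 4 (0.48 log units; beyond the scatter), which shows that the activity at this position depends on more than the presence of an amino group, although this step alters the amino group and the chain length together. Compound 1 and compound 3 each have only a limit, so the steps from them are bounded and the true gaps may be larger: the limit of > 50000 nM in this assay, at which 2 of the 4 values shown sit.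

The compounds shown cannot separate the amino group's identity from the chain length, a question that a 2-(dimethylamino)ethyl or a 3-(diethylamino)propyl chain would address. As far as these compounds go, whether an amine is needed at all also stays open, since a hydroxyl group at the end of the same chain, or a longer chain carrying dimethylamino, lies outside this set.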